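Central-ring nitro added to the bis-trifluoromethyl analogue

The compounds below may be only part of what the source reports. "The series", "measured", "known", "first", "only" and "open" are said of these compounds alone.

Three compounds of this series have been run in a functional assay on HeLa cells (Homo sapiens) for cytotoxicity, read by MTT assay, with a stated time of 48 h; a lower number here means a stronger inhibitor, a higher number a weaker inhibitor. Compound 1 `O=[N+]([O-])c1cc(-c2nc3ccc([N+](=O)[O-])cc3[nH]2)cc(-c2nc3ccc([N+](=O)[O-])cc3[nH]2)c1`, which carries nitro groups on the shared core and on the central ring, gives 1200 nM. Compound 2 `Brc1ccc2nc(-c3cccc(-c4nc5ccc(Br)cc5[nH]4)c3)[nH]c2c1`, the bromo analogue without a central substituent, gives 21100 nM. Compound 3 `FC(F)(F)c1ccc2nc(-c3cccc(-c4nc5ccc(C(F)(F)F)cc5[nH]4)c3)[nH]c2c1`, the trifluoromethyl analogue, gives 8000 nM in this assay, the second highest of the three numbers; its gap to compound 2 and its gap to compound 1 both lie beyond the scatter.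

Compound 4 `O=[N+]([O-])c1cc(-c2nc3ccc(C(F)(F)F)cc3[nH]2)cc(-c2nc3ccc(C(F)(F)F)cc3[nH]2)c1` is not yet measured. It differs from compound 3 by nitro in place of hydrogen on an aromatic carbon. Among the measured compounds shown here, no measured pair shows this change on its own; compound 1 is the only measured compound with a central nitro, but it also differs from compound 3 in the groups on the shared core. The value of compound 1, 1200 nM, is therefore only a loose pointer.

A downward step is expected, a 2.7-fold lower number from compound 3 to compound 4 (0.43 log units; beyond the scatter), on the strength of compound 1 at 1200 nM against compound 3 at 8000 nM. Compound 4 is estimated at 3000 nM, within 1000 nM to 10000 nM.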

Compound 4, half-maximal inhibitory concentration: 1900 nM
Estimate against measurement, compound 4: 1.6-fold (0.20 log units) above; the range from low to high includes it.
By their numbers in this assay, from the lowest: compounds 1 and 4 (each within the scatter of the next); then compound 3; then compound 2.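

In this assay, the change of hydrogen to nitro on this aromatic carbon, meta to two large groups, can now be read on its own: it gives a 4.2-fold lower number from compound 3 to compound 4 (0.62 log units; beyond the scatter) with the trifluoromethyl groups held constant. This shows that the central nitro alone shifts the number, a point that compound 1 could not settle because its core groups also differ from those of compound 3. With the central nitro present, compound 4 lies within the scatter of compound 1 at 1200 nM, so trifluoromethyl and nitro on the shared core are not told apart in this pair, and nothing measured here accounts for the step.

The compounds shown leave open whether an amine or a carboxylic acid on this same carbon would move the number in the same direction. They also leave open whether nitro here gives a step of similar size on the bromo analogue, compound 2.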